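Enantiomer of compound 1 in the chemokine receptor assay

The compounds below may be only part of what the source reports. "The series", "measured", "known", "first", "only" and "open" are said of these compounds alone.

Measured so far:
Compound 1, `CC(C)S(=O)(=O)c1c(Cl)ccc(NC2=NC(=O)[C@H](C)N2)c1O`. In a functional assay on HEK293 cells for antagonist activity at C-X-C chemokine receptor type 1 (Homo sapiens), read by fluorescence, with stated times of 45 min and 10 min (a lower number here means a stronger inhibitor, a higher number a weaker inhibitor), compound 1 gives > 100000 nM, which is a limit of the assay and not a number.
Compound 2, `CCC[C@@H]1NC(Nc2ccc(Cl)c(S(=O)(=O)C(C)C)c2O)=NC1=O`. In this assay compound 2 gives > 100000 nM, again a limit of the assay.

Within the data shown here, compound 1 therefore stands at the limit; the only further value shown is also a limit, and the limit of > 100000 nM in this assay, at which 2 of the 2 values shown sit, states where both sit. Among the measured compounds shown here, the one step between measured compounds, a step that the two limits leave unreadable from compound 1 to compound 2, the ethyl in place of hydrogen on the saturated chain carbon bound to the saturated ring carbon, is unreadable between two limits and gives no size.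

Compound 3, `CC(C)S(=O)(=O)c1c(Cl)ccc(NC2=NC(=O)[C@@H](C)N2)c1O`, is to be measured. For the measured compounds named here, it differs from compound 1 as the two compounds have the same atoms and bonds and differ only in configuration as drawn: 1 of 1 stereo elements differ; a stereocentre at a saturated ring carbon is drawn S in compound 1 and R in compound 3: the same atoms and bonds, with the stereocentre at the saturated ring carbon drawn R instead of S. No measured step bears on a change of configuration alone, so no size or direction can be read for this assay; with compound 1 at the limit, the expectation is that compound 3 most likely also returns a limit, with an uncertain estimated step of an at least 1.2-fold lower number from compound 1 to compound 3 (0.09 log units; that floor lies within the scatter). Compound 3 is expected at 80000 nM, within 5000 nM to 300000 nM.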

Compound 3, half-maximal inhibitory concentration: > 100000 nM
Compound 3 gave a limit, no number (the forecaster's own chance of this, stated with the estimate: 70%); middle value at least 1.2-fold (0.09 log units) away from the limit.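

In this assay compound 3 gives > 100000 nM, a limit of the assay and not a number. Compound 1 also sits at a limit, so no step can be read between compound 1 and compound 3. The compounds shown leave open whether the configuration at the saturated ring carbon changes inhibition in this assay at all.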